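Replacing 4-phenylphenyl with naphthalen-2-yl in a weak inhibitor

This account rests on a few compounds, and the source may have more. Where it says the series, first, only, none or still open, it means among the compounds named here.

Compound 1 `O=C1/C(=C\c2ccccc2)c2c(ncn2COCc2ccccc2)CCN1Cc1ccc(-c2ccccc2)cc1`: 48300 nM
Compound 2 `COc1cc(/C=C2\C(=O)N(Cc3ccccc3)CCc3ncn(COCc4ccccc4)c32)cc(OC)c1OC`: 8970 nM

In a functional assay on A2780 cells (Homo sapiens) for inhibition, read by MTT assay, with a stated time of 72 h (on this read-out higher numbers stand for weaker inhibition and lower numbers for stronger inhibition), compound 1 has the higher of the two numbers, and compound 2 lies lower by more than the scatter. Compound 3 `O=C1/C(=C\c2ccccc2)c2c(ncn2COCc2ccccc2)CCN1Cc1ccc2ccccc2c1` carries naphthalen-2-yl in place of 4-phenylphenyl on a saturated chain carbon bound to an amide-type nitrogen in a ring. Going by the values given here, no measured pair tests this change. Both groups have two six-membered aromatic rings of carbon only, so no step beyond the scatter is expected in this assay. The estimated step is a 1.4-fold lower number from compound 1 to compound 3 (0.14 log units; within the scatter). Compound 3 is expected at 35000 nM, with an estimated range of 12000 nM to 90000 nM.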

Compound 3, half-maximal inhibitory concentration: 72800 nM
For compound 3 the middle estimate is 2.1-fold (0.32 log units) below the measured one; measured number inside the range.
By their numbers in this assay, from the lowest: compound 2; then compounds 1 and 3 (each within the scatter of the next).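

In this assay, this position now has its first direct test, which gives a 1.5-fold higher number from compound 1 to compound 3 (0.18 log units; within the scatter). Within the scatter, naphthalen-2-yl and 4-phenylphenyl on a saturated chain carbon bound to an amide-type nitrogen in a ring cannot be told apart, so this swap between two all-carbon aromatic groups does not separate the two compounds. Nothing available accounts for the small difference between them. The compounds shown leave open whether an amine or a carboxylic acid at this place would give a step beyond the scatter.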